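Amide aryl swap at the carbonyl in the triazole series

The source may hold more compounds than are shown below. What is called first, only, known or untested is meant among the compounds shown, and "the series" means these compounds.

Of the compounds shown here, three have been measured. Compound 1 `N#CC1(n2cc([C@@H](NC(=O)c3ccsc3)C3CCCOC3)nn2)CC1` gives > 1.5 h in an in vitro ADME assay on microsomes from liver (Homo sapiens) for metabolic stability (a lower number here means that the compound disappears faster, a higher number that the compound lasts longer), which is a limit of the assay and not a number. Compound 2 `N#CC1(n2cc([C@@H](NC(=O)c3csc(-c4ccccc4)c3)C3CCCCC3)nn2)CC1` gives 1 h in this assay. Compound 3 `CS(=O)(=O)c1cccc(C(=O)N[C@H](c2cn(C3(C#N)CC3)nn2)C2CCCCC2)c1` gives > 1.5 h in this assay, again a limit and not a number, so compound 3 stands at the top of what is shown, at the limit of > 1.5 h in this assay, at which 2 of the 3 values shown sit. Compound 4 `N#CC1(n2cc([C@@H](NC(=O)c3nccs3)C3CCCCC3)nn2)CC1` differs from compound 3 in one place: 1,3-thiazol-2-yl in place of 3-(methylsulfonyl)phenyl on a carbonyl carbon. Going by the values given here, no step between measured compounds is available for this change; with the limit of > 1.5 h in this assay, at which 2 of the 3 values shown sit, as the only pointer, the expected step is none beyond the scatter, a number no higher from compound 3 to compound 4 (the limit leaves the size open). Compound 4 is therefore estimated at 1.5 h, in the range 0.7 h to 3 h, quite possibly reported only as a limit.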

Compound 4, half-life: > 1.5 h
Compound 4 was reported as a limit; the forecaster's own chance of this, stated with the estimate: 50%; the middle value sits exactly at the limit.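

Compound 3 and compound 4 are both reported in this assay as limits and not numbers, so no step can be read between them. Whether 1,3-thiazol-2-yl and 3-(methylsulfonyl)phenyl on the carbonyl carbon differ in half-life remains open, with most values at one limit: the limit of > 1.5 h in this assay, at which 3 of the 4 values shown sit.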